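The source may hold more compounds than are shown below. What is called first, only, known or untested is meant among the compounds shown, and "the series" means these compounds.

Measured so far: compound 1 `N#CC1CN1C(=O)Nc1ccc(F)cc1`, 7300 nM; compound 2 `CC(C)(C)NC(=O)N1CC1C#N`, 132000 nM.

In a functional assay on L1210 cells (Mus musculus) for inhibition, read by MTT assay (a lower number here means a stronger inhibitor, a higher number a weaker inhibitor), compound 1 gives 7300 nM, the lower of the two numbers; compound 2 gives 132000 nM, a gap beyond the scatter. Compound 3 `CCOC(=O)c1ccc(NC(=O)N2CC2C#N)cc1` keeps the shared core of compound 1 and differs only by ethoxycarbonyl in place of fluoro on an aromatic carbon. Within the data shown here, no measured pair covers this change, so no step beyond the scatter is expected in this assay, in either direction. Compound 3 is accordingly estimated at 5500 nM, range 1500 nM to 20000 nM. The step this estimate implies is a 1.3-fold lower number from compound 1 to compound 3 (0.12 log units; within the scatter), expected to stay within the scatter.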

Compound 3, half-maximal inhibitory concentration: 9700 nM
For compound 3 the middle estimate is 1.8-fold (0.25 log units) below the measured one; low and high end bracket the measured number.
By their numbers in this assay, from the lowest: compounds 1 and 3 (each within the scatter of the next); then compound 2.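

In this assay the swap of fluoro for ethoxycarbonyl on an aromatic carbon gives a 1.3-fold higher number from compound 1 to compound 3 (0.12 log units; within the scatter) and so no separation between the two compounds. This position, para to a group of 8 heavy atoms, therefore carries the 5 heavy atoms and 2 hydrogen-bond acceptors of ethoxycarbonyl with no step beyond the scatter. Nothing measured here bears on the reason for this result.

Open, from the compounds shown here alone, is whether a carboxylic acid or an amine at this position would leave the number in the same range. A longer chain on the ester oxygen is equally untested in these compounds.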